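Swapping the Aryl Group on the Ring Nitrogen

This account rests on a few compounds, and the source may have more. Where it says the series, first, only, none or still open, it means among the compounds named here.

Compound 1 `CC1=NN(c2cccc(Cl)c2)C(=O)C12C=CC(=O)C=C2c1cccc(C)c1` is one of two measured compounds here. In a functional assay on HCT-116 cells (Homo sapiens) for antiproliferative activity, read by CCK-8 assay, with a stated time of 72 h (on this read-out lower numbers stand for stronger inhibition and higher numbers for weaker inhibition), compound 1 gives 3740 nM. Its companion, compound 2 `CC1=NN(c2cccc(Cl)c2)C(=O)C12C=CC(=O)C=C2c1ccc(C)cc1`, differs from it only by the change described in a 1.6-fold lower number from compound 1 to compound 2 (0.19 log units; within the scatter); in this assay compound 2 gives 2400 nM. The two numbers therefore lie within the scatter of each other, and neither can be called stronger.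

Compound 3 `CC1=NN(c2ccc(Br)cc2)C(=O)C12C=CC(=O)C=C2c1cccc(C)c1` is not yet measured. It differs from compound 1 by 4-bromophenyl in place of 3-chlorophenyl on an amide-type nitrogen in a ring. For the measured compounds named here, no measured step touches this aryl group on the ring nitrogen: the only step available concerns a different place and stayed within the scatter. With nothing to indicate a direction, the expected step of a 1.1-fold lower number from compound 1 to compound 3 (0.03 log units; within the scatter) is estimated to stay within the scatter. The estimate for compound 3 in this assay is 3500 nM, within a range from 1200 nM to 10000 nM.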

Compound 3, half-maximal inhibitory concentration: > 100000 nM
Compound 3 gave a limit, no number; the forecaster's own chance of this, stated with the estimate: 10%; middle value at least 28-fold (1.45 log units) away from the limit.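

Replacing 3-chlorophenyl with 4-bromophenyl on the amide-type nitrogen gives an at least 26-fold higher number from compound 1 to compound 3 (1.42 log units; beyond the scatter), so this position responds strongly, whereas the earlier step on the double-bonded ring carbon stayed within the scatter. The two groups have the same count of heavy atoms and the same single six-membered aromatic ring, so a change that leaves those counts untouched is enough to weaken inhibition sharply in this pair. The result for compound 3 is a limit and not a number, so the true size of the step stays unknown: the limit of > 100000 nM in this assay, at which 1 of the 3 values shown sits.

This change alters both the halogen and its place on the ring, and the compounds shown cannot separate the two. On these data alone, a 4-chlorophenyl or 3-bromophenyl group on the same nitrogen would tell them apart, and whether a plain phenyl group is tolerated there also remains open.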